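From 3-chlorobenzyl to 2-chlorobenzyl: compound 2 and compound 4

The source may hold more compounds than are shown below. What is called first, only, known or untested is meant among the compounds shown, and "the series" means these compounds.

- Compound 1 `O=C1/C(=C/c2ccccc2F)CN(C(=S)SCc2cn(Cc3ccccc3Cl)nn2)C/C1=C\c1ccccc1F` gives > 80000 nM (a limit)
- Compound 2 `Cc1ccc(/C=C2\CN(Cc3cn(Cc4cccc(Cl)c4)nn3)C/C(=C\c3ccc(C)cc3)C2=O)cc1` gives 29300 nM (a measured number)
- Compound 3 `COc1ccc(/C=C2\CN(Cc3cn(Cc4ccccc4F)nn3)C/C(=C\c3ccc(OC)cc3)C2=O)cc1` gives 39900 nM (a measured number)

In a functional assay on PC-3 cells (Homo sapiens) for cytotoxicity, read by MTT assay, with a stated time of 24 h (on this read-out higher numbers stand for weaker inhibition and lower numbers for stronger inhibition), compound 2 gives 29300 nM and compound 3 gives 39900 nM which places the two within the usual scatter of each other. Compound 1 reads > 80000 nM which is a limit of the assay and not a number.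

Set against compound 2, compound 4 `Cc1ccc(/C=C2\CN(Cc3cn(Cc4ccccc4Cl)nn3)C/C(=C\c3ccc(C)cc3)C2=O)cc1` carries 2-chlorophenyl in place of 3-chlorophenyl on a saturated chain carbon bound to an aromatic nitrogen. The two have the same atoms, joined differently.

Among the compounds with values here, no two measured compounds differ in one place alone, so the data offer no direct guide to this change. Within the data shown here, the expectation therefore starts from compound 2 at 29300 nM and foresees no step in this assay beyond the scatter. The estimate amounts to an expected change a 1.0-fold higher number from compound 2 to compound 4 (0.01 log units; within the scatter) and no more. Compound 4 is expected to read 30000 nM (estimated range 12000 nM to 70000 nM).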

Compound 4, half-maximal inhibitory concentration: 8900 nM
Estimate against measurement, compound 4: 3.4-fold (0.53 log units) above, outside the stated range (below it).
By their numbers in this assay, from the lowest: compound 4; then compounds 2 and 3 (each within the scatter of the next). At a limit, above all of these: compound 1.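

In this assay, putting 2-chlorophenyl in place of 3-chlorophenyl on a saturated chain carbon bound to an aromatic nitrogen gives a step beyond the scatter (a 3.3-fold lower number from compound 2 to compound 4 (0.52 log units; beyond the scatter)), the first effect in this set that can be read from a single change. The two compounds hold the same atoms, joined differently, so a rearrangement alone, with nothing gained or lost, is enough to move the number at this position. Nothing among the measurements shown accounts for this step.

From the compounds shown here alone, whether the same step would appear with the other arms of the shared core, such as those of compound 3, remains open, since compound 3 differs from compound 4 in more than one place. Also open, going by these compounds, is how a 4-chlorobenzyl group or an unsubstituted benzyl group would read at this position.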